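Dienone series: chloro for methoxy on the aryl ring

The source may hold more compounds than are shown below. What is called first, only, known or untested is meant among the compounds shown, and "the series" means these compounds.

Among the compounds with values here, compound 1 `COc1ccc(/C=C/C=C/C(=O)c2cc(Cl)ccc2O)cc1` gives 153 nM in an in vitro assay on cells for inhibition of Amine oxidase [flavin-containing] B (Homo sapiens), read by Amplex Red, with a stated time of 15 min (a lower number here means a stronger inhibitor, a higher number a weaker inhibitor), the lowest of the two numbers so far. Compound 2 `COc1ccc(/C=C/C=C/C(=O)c2ccccc2O)cc1` gives 1810 nM in this assay, and the step of a 12-fold higher number from compound 1 to compound 2 (1.07 log units; beyond the scatter) is hydrogen in place of chloro on an aromatic carbon. Compound 3 `O=C(/C=C/C=C/c1ccc(Cl)cc1)c1cc(Cl)ccc1O` differs from compound 1 by chloro in place of methoxy on an aromatic carbon. Within the data shown here, no measured step touches the methoxy; the one known step concerns the other ring, so it does not bear on this change directly. A step within the scatter in this assay is expected, direction uncertain. Compound 3 is therefore estimated at 110 nM, range 30 nM to 400 nM, an expected step of a 1.4-fold lower number from compound 1 to compound 3 (0.14 log units; within the scatter).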

Compound 3, half-maximal inhibitory concentration: 1460 nM
The estimate for compound 3 lay 13-fold (1.12 log units) below the measured number, and the stated range ends below it.
By their numbers in this assay, from the lowest: compound 1; then compounds 3 and 2 (each within the scatter of the next).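

Methoxy at this place is not interchangeable with chloro: in this assay the swap gives a 9.5-fold higher number from compound 1 to compound 3 (0.98 log units; beyond the scatter) and is the first measured step on this ring. Each single change from compound 1 now known, this one and hydrogen for chloro on the other ring, raises the number beyond the scatter. No evidence on the origin of this step is available.

From the compounds shown here alone, whether a hydroxyl, an ethoxy, a methyl or an amine at this place would stay close to compound 1 remains open. Also open, going by these compounds, is whether the swap gives a similar step without the chloro on the other ring.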